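Notes on the step from compound 2 to compound 4

A few compounds are considered here, and "the series" means these few. Any claim that something is new, unique, unknown or untested is made for them only; others in the source may bear on it.

Measured so far in a functional assay on HEK293 cells with Glucose-dependent insulinotropic receptor (Homo sapiens) as the target, read by cAMP accumulation, with a stated time of 60 min; a lower number here means a smaller maximal response, a higher number a larger maximal response:
compound 1, `CCCS(=O)(=O)N1CC=C(c2ccc3c(c2)CC(C2CCN(C(=O)OC(C)C)CC2)O3)CC1`, gives 61%
compound 2, `CCCS(=O)(=O)N1CC=C(c2ccc3c(c2)CC(C2CCN(C(=O)OC4CCCCC4)CC2)O3)CC1`, gives 56%
compound 3, `CCCS(=O)(=O)N1CC=C(c2ccc3c(c2)CC(C2CCN(c4ncc(C(F)(F)F)cn4)CC2)O3)CC1`, gives 118%

Compound 2 holds the lowest of the three numbers in this assay. Its nearest neighbour is compound 1: the step of a number 5 percentage points lower from compound 1 to compound 2 (within the scatter) is within the scatter, so the two carbamates are not separated. Compound 3 stands far above both: a number 57 percentage points higher from compound 1 to compound 3 (beyond the scatter) and a number 62 percentage points higher from compound 2 to compound 3 (beyond the scatter) are both large and well beyond the scatter.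

Compound 4, `CCCc1cnc(N2CCC(C3Cc4cc(C5=CCN(S(=O)(=O)CCC)CC5)ccc4O3)CC2)nc1`, has not been measured. Relative to compound 2 the change is 5-propylpyrimidin-2-yl in place of cyclohexyloxycarbonyl on an amine nitrogen in a ring. Within the data shown here, the step that bears directly on this is the one from compound 2 to compound 3, where the same cyclohexyloxycarbonyl left and a pyrimidin-2-yl entered on the same amine nitrogen; that step was large and upward. Among the measured compounds shown here, the only difference between compound 3 and compound 4 is a propyl in place of the trifluoromethyl on the pyrimidine ring, a variation for which no measured pair exists. The expectation is therefore a large upward step, a number 52 percentage points higher from compound 2 to compound 4 (beyond the scatter), in this assay.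

Compound 4 is estimated at 108% in this assay, with a likely range from 82% to 134%.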

Compound 4, largest response reached (Emax), in percent of the reference or control that the assay uses: 107%
Compound 4: middle estimate off by 1 percentage points, on the high side; the range from low to high includes it.
By their numbers in this assay, from the lowest: compounds 2 and 1 (each within the scatter of the next); then compound 4; then compound 3.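

In this assay the large rise seen with the earlier pyrimidine does not depend on the trifluoromethyl group: it appears again in the step of a number 51 percentage points higher from compound 2 to compound 4 (beyond the scatter) and in the step of a number 46 percentage points higher from compound 1 to compound 4 (beyond the scatter) when 5-propylpyrimidin-2-yl stands on the same amine nitrogen. Both pyrimidines now stand above both carbamates, with no compound shown going against this, while the first measured change on the pyrimidine ring itself, propyl in place of trifluoromethyl, gives a much smaller step, a number 11 percentage points lower from compound 3 to compound 4 (beyond the scatter) but still beyond the scatter. The replacement of the carbamate therefore accounts for most of the gain, and the group on the pyrimidine ring adjusts it only modestly, although no data at hand say what lies behind either step.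

As far as these compounds go, it remains open whether the pyrimidine ring is needed at all, or whether a pyridine or a plain phenyl ring on this amine nitrogen would give a similar response. Also open, from the compounds shown here alone, is how the response would move with a methyl group, a nitrile or a longer chain in place of the propyl.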